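A few compounds are considered here, and "the series" means these few. Any claim that something is new, unique, unknown or untested is made for them only; others in the source may bear on it.

In an ADME assay on MRC5 cells (Homo sapiens) for cytotoxicity, read by MTT assay, with a stated time of 72 h (a lower number here means a stronger inhibitor, a higher number a weaker inhibitor), compound 1 `CC1=CCC[C@H]2[C@](C)(CC3=CC(=O)C=C(NCCC(=O)O)C3=O)[C@@H](C)CC[C@]12C` gives 80800 nM. Compound 2 `CC(C)(C)C1=CC(=O)C=C(NCC(=O)O)C1=O` reaches only a limit of this assay, > 200000 nM, which is the limit of > 200000 nM in this assay, at which 1 of the 2 values shown sits. On the numbers shown, compound 2 therefore stands without a value of its own, at the weak end. Compound 3 `C[C@H](NC1=CC(=O)C=C(C(C)(C)C)C1=O)C(=O)O` differs from compound 2 by methyl in place of hydrogen on a saturated chain carbon bound to an amine nitrogen and a carbonyl carbon. Among the compounds with values here, no measured pair shows what this change does in this assay, so the expected step is a step that the limit leaves unreadable from compound 2 to compound 3, none beyond the usual scatter. Compound 3 is accordingly estimated at 250000 nM, between 120000 nM and 600000 nM, and may again be reported only as a limit.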

Compound 3, half-maximal inhibitory concentration: > 200000 nM
Compound 3: only a limit was reported (the forecaster's own chance of this, stated with the estimate: 75%); the middle value does not contradict the limit.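

Compound 2 and compound 3 are both reported only as limits in this assay, so no step can be read between them. Going by these compounds, what methyl in place of hydrogen on that saturated chain carbon does there remains open.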